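Extending the chain on the aromatic nitrogen

This account rests on a few compounds, and the source may have more. Where it says the series, first, only, none or still open, it means among the compounds named here.

Measured compounds:
Compound 1 `CCn1c(/C=C2/C(=O)Nc3ccc(F)cc32)nc2ccccc21`: 40600 nM
Compound 2 `CC(C)n1c(/C=C2/C(=O)Nc3ccc(F)cc32)nc2ccccc21`: 24500 nM
Compound 3 `Cn1c(/C=C2/C(=O)Nc3ccc(Cl)cc32)nc2ccccc21`: 38900 nM

All three compounds were tested in a functional assay on DU-145 cells (Homo sapiens) for cytotoxicity, read by MTT assay, with a stated time of 48 h; a higher number here means a weaker inhibitor, a lower number a stronger inhibitor. Compound 1 gives 40600 nM in this assay, and compound 2 gives 24500 nM. The two differ by methyl in place of hydrogen on a saturated chain carbon bound to an aromatic nitrogen and a saturated chain carbon, and the step of a 1.7-fold lower number from compound 1 to compound 2 (0.22 log units; within the scatter) stays within the usual scatter, so no real change in potency can be read from it. Compound 3 gives 38900 nM; its value sits close to that of compound 1 and that of compound 2, all three lying within the scatter of one another. The difference between the core of compound 1 and the core of compound 3 is not broken down here.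

Compound 4 `CCn1c(/C=C2/C(=O)Nc3ccc(Cl)cc32)nc2ccccc21` has not yet been measured. It differs from compound 3 by methyl in place of hydrogen on a saturated chain carbon bound to an aromatic nitrogen. Within the data shown here, this is the same kind of change as the one from compound 1 to compound 2, although the surroundings differ: in the earlier pair the carbon carrying the new methyl is bound to an aromatic nitrogen and a saturated chain carbon, whereas in the new pair it is bound only to an aromatic nitrogen. Because the earlier step of a 1.7-fold lower number from compound 1 to compound 2 (0.22 log units; within the scatter) was small, compound 4 is expected to show a step of about a 1.3-fold lower number from compound 3 to compound 4 (0.11 log units; within the scatter) in this assay, again within the scatter. Compound 4 is therefore estimated at 30000 nM, with a plausible range from 14000 nM to 65000 nM.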

Compound 4, half-maximal inhibitory concentration: > 50000 nM
Compound 4 gave a limit, no number; the forecaster's own chance of this, stated with the estimate: 10%; at least 1.6-fold (0.22 log units) between middle value and limit.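

In this assay compound 4 gives > 50000 nM, which is a limit of the assay and not a number, so the steps that reach it have only a floor. Read against that limit, methyl in place of hydrogen on a saturated chain carbon bound to an aromatic nitrogen gives an at least 1.2-fold higher number from compound 3 to compound 4 (0.10 log units; that floor lies within the scatter), while chloro in place of fluoro on an aromatic carbon gives an at least 1.2-fold higher number from compound 1 to compound 4 (0.09 log units; that floor lies within the scatter). This shows that the small step seen on the first core cannot simply be read across to the second, yet it does not show that the change behaves differently there, and neither a shared effect nor a reversal can be claimed from these two pairs: the same change on two cores in this assay, a 1.7-fold lower number (0.22 log units; within the scatter) from compound 1 to compound 2 and an at least 1.2-fold higher number (0.10 log units; that floor lies within the scatter) from compound 3 to compound 4; the limit leaves it open whether they differ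

The compounds shown leave open how a longer chain on the aromatic nitrogen, or a chain carrying an amine or a carboxylic acid, would read in this assay, and whether any such group would give a step beyond the scatter. They also leave open how far the value of compound 4 lies past its limit, and with it the true size of both steps that end at that compound.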